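A few compounds are considered here, and "the series" means these few. Any claim that something is new, unique, unknown or untested is made for them only; others in the source may bear on it.

Measured so far:
compound 1 `O=C(Nc1cccc(CN2CCCC2)c1)C1CCCN(C(=O)c2cc(C(F)(F)F)cc(C(F)(F)F)c2)C1` — 51%
compound 2 `C=CCOc1cccc(NC(=O)C2CCCN(C(=O)c3cc(C(F)(F)F)cc(C(F)(F)F)c3)C2)c1` — 0%

Among the measured compounds shown here, in an ADME assay on PC-3 cells (Homo sapiens) for cytotoxicity, read by WST assay, tested at 100 uM (on this read-out higher numbers stand for more inhibition at the one concentration tested (going by the name of the read-out) and lower numbers for less inhibition), compound 2 gives the lower of the two numbers; the only neighbour is compound 1, and the step of a number 51 percentage points lower from compound 1 to compound 2 (beyond the scatter) is the single measured change in the set. Compound 3 `O=C(Nc1cccc(Oc2nccc(C(F)(F)F)c2Cl)c1)C1CCCN(C(=O)c2cc(C(F)(F)F)cc(C(F)(F)F)c2)C1` carries the change (3-chloro-4-(trifluoromethyl)pyridin-2-yl in place of allyl on an oxygen on an aromatic ring). For the measured compounds named here, no measured step covers this swap, so the expectation leans on the stand of compound 2 alone, with the width of the step to compound 1 as the scale of what one change has done here. A moderate rise, a number 20 percentage points higher from compound 2 to compound 3 (beyond the scatter), is expected. Compound 3 is estimated at 20%, range 0% to 55%.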

Compound 3, a percentage reported as inhibition, at one concentration (the size of the read-out at that concentration, not a potency): 0%
Compound 3: the middle estimate sits 20 percentage points above what was measured; low and high end bracket the measured number.
By their numbers in this assay, from the lowest: compounds 2 and 3 (each within the scatter of the next); then compound 1.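

In this assay the oxygen on the aromatic ring takes a far larger group with no change at the digits printed from compound 2 to compound 3 (within the scatter) on exchanging allyl for 3-chloro-4-(trifluoromethyl)pyridin-2-yl. The gap to the (pyrrolidin-1-yl)methyl compound recurs with this second oxygen-linked group, as a number 51 percentage points lower from compound 1 to compound 3 (beyond the scatter) shows alongside the earlier step. Nothing on hand accounts for that gap. The compounds shown leave open whether the read-out follows the pyrrolidine itself or any amine on that methyl carbon. A morpholin-4-ylmethyl or dimethylaminomethyl group at the same aromatic carbon would separate these readings.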